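Bromo for Nitro on the Benzyl Arm of Compound 1

This account rests on a few compounds, and the source may have more. Where it says the series, first, only, none or still open, it means among the compounds named here.

Compound 1 `O=[N+]([O-])c1cccc(CSc2nnc(-c3ccc4c(c3)OCCO4)n2-c2ccccc2)c1` is assessed in a functional assay on HeLa cells (Homo sapiens) for antiproliferative activity, read by MTT assay, with a stated time of 24 h (on this read-out higher numbers stand for weaker inhibition and lower numbers for stronger inhibition), where compound 1 gives 45200 nM, the highest of the two numbers recorded. Compound 2 `Fc1ccccc1CSc1nnc(-c2ccc3c(c2)OCCO3)n1-c1ccccc1` gives 24300 nM, and the step of a 1.9-fold lower number from compound 1 to compound 2 (0.27 log units; within the scatter) stays within the scatter. Compound 3 `Brc1ccccc1CSc1nnc(-c2ccc3c(c2)OCCO3)n1-c1ccccc1` reaches only the limit > 100000 nM, so no number is known for it. The steps of an at least 2.2-fold higher number from compound 1 to compound 3 (0.34 log units; beyond the scatter) and an at least 4.1-fold higher number from compound 2 to compound 3 (0.61 log units; beyond the scatter) both run to higher numbers. Compound 4 `Brc1cccc(CSc2nnc(-c3ccc4c(c3)OCCO4)n2-c2ccccc2)c1` is not yet measured; it differs from compound 1 by bromo in place of nitro on an aromatic carbon. The two bromo-bearing steps, both ending at the limit (the limit of > 100000 nM in this assay, at which 1 of the 3 values shown sits), suggest a modest move toward higher numbers, though neither sits at the same place as this change. Compound 4 is therefore expected to give about 80000 nM, between 30000 nM and 200000 nM, a step of a 1.8-fold higher number from compound 1 to compound 4 (0.25 log units; within the scatter).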

Compound 4, half-maximal inhibitory concentration: 44200 nM
The estimate for compound 4 lay 1.8-fold (0.26 log units) above the measured number, and the stated range covers the measured number.
By their numbers in this assay, from the lowest: compounds 2, 4 and 1 (each within the scatter of the next). At a limit, above all of these: compound 3.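

In this assay, bromo in place of nitro on an aromatic carbon, meta to a large group, leaves the two compounds indistinguishable (a 1.0-fold lower number from compound 1 to compound 4 (0.01 log units; within the scatter)), so the nitro and its hydrogen-bond acceptors are not needed at this position for this level of activity. The place of the bromo does count, as moving it to the 3-bromophenyl arrangement gives a step beyond the scatter (an at least 2.2-fold lower number from compound 3 to compound 4 (0.35 log units; beyond the scatter)), while the gap to the 2-fluorophenyl compound stays within it (a 1.8-fold higher number from compound 2 to compound 4 (0.26 log units; within the scatter)). Compound 3 stands at a limit, not a number: the limit of > 100000 nM in this assay, at which 1 of the 4 values shown sits. Going by these compounds, whether an amine or a carboxylic acid at this same place would match compound 1 remains open, as does the effect of a longer chain between the sulfur and the ring.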